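From pyrrolidin-1-yl to 2,6-dimethylmorpholin-4-yl on the carbonyl carbon

The source may report more compounds than this note shows. Statements on the series, on what has been measured and on what is new or still open speak of the compounds shown alone.

Measured so far in a functional assay on DU-145 cells (Homo sapiens) for inhibition, read by MTT assay, with a stated time of 48 h (on this read-out higher numbers stand for weaker inhibition and lower numbers for stronger inhibition), as follows
Compound 1 `Cn1c(/C=C2\SC(=O)N(CC(=O)N3CCCCC3)C2=O)nc2ccccc21` gives > 50000 nM as a limit
Compound 2 `Cn1c(/C=C2\SC(=O)N(CC(=O)N3CCCC3)C2=O)nc2ccccc21` gives > 50000 nM as a limit

Compound 2 has no number on this read-out, only the limit > 50000 nM as its standing. The next compound is compound 3 `CC1CN(C(=O)CN2C(=O)S/C(=C\c3nc4ccccc4n3C)C2=O)CC(C)O1` which carries the change 2,6-dimethylmorpholin-4-yl in place of pyrrolidin-1-yl on a carbonyl carbon with 2,6-dimethylmorpholin-4-yl in place of pyrrolidin-1-yl on a carbonyl carbon.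

Going by the values given here, one measured step bears on this change, since it also exchanges the group on that carbonyl carbon. It is a step that the two limits leave unreadable from compound 1 to compound 2 and it offers no size to carry forward. The wider evidence is the limit of > 50000 nM in this assay, at which 2 of the 2 values shown sit, and so no exchange at this carbonyl carbon has yet been seen to move the read-out in this assay in either direction.

The expected step is a number no higher from compound 2 to compound 3 (the limit leaves the size open) with no size beyond the scatter and no direction expected. For compound 3 the estimate is 50000 nM with an expected range from 12000 nM to 100000 nM and a report as a limit is the likeliest outcome.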

Compound 3, half-maximal inhibitory concentration: > 50000 nM
Compound 3: only a limit was reported (the forecaster's own chance of this, stated with the estimate: 70%); the middle value sits exactly at the limit.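

In this assay compound 3 gives > 50000 nM, which is a limit and not a number. Going by these compounds alone, no step can therefore be read among compound 1, compound 2 and compound 3. The compounds shown leave open whether any exchange of the group on the carbonyl carbon moves the read-out in this assay: the limit of > 50000 nM in this assay, at which 3 of the 3 values shown sit.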